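Sulfonylurea analogues: one added methyl on a thiophene ring

A few compounds are considered here, and "the series" means these few. Any claim that something is new, unique, unknown or untested is made for them only; others in the source may bear on it.

The three measured compounds and their values in a functional assay on the whole organism (6C3HED cells, Mus musculus) for inhibition, at a dose of 150 mg/kg by the oral route (a lower number here means less inhibition, a higher number more inhibition at the dose given (going by the name of the read-out)), are: compound 1 `COc1ccc(S(=O)(=O)NC(=O)Nc2ccc(Cl)cc2)s1`, 93%; compound 2 `CCOc1ccc(S(=O)(=O)NC(=O)Nc2ccc(Cl)cc2)s1`, 69%; compound 3 `Cc1cc(S(=O)(=O)NC(=O)Nc2ccc(Cl)cc2)sc1C`, 42%.

All three share a sulfonylurea linked to a chlorophenyl group and differ only in the thiophene ring attached to the sulfonyl sulfur. Compound 2 differs from compound 1 by methyl in place of hydrogen on a saturated chain carbon bound to an oxygen on an aromatic ring, and this gave a number 24 percentage points lower from compound 1 to compound 2 (beyond the scatter). Compound 3 carries a different ring altogether, (4,5-dimethylthiophen-2-yl in place of 5-methoxythiophen-2-yl on a sulfonyl sulfur), and this gave a number 51 percentage points lower from compound 1 to compound 3 (beyond the scatter), leaving compound 3 with the lowest number of the three.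

Compound 4 `CCc1sc(S(=O)(=O)NC(=O)Nc2ccc(Cl)cc2)cc1C` is not yet measured. It differs from compound 3 by methyl in place of hydrogen on a saturated chain carbon bound to an aromatic carbon. Within the data shown here, this is the same kind of change as the one from compound 1 to compound 2, but not the same: there the new methyl went onto a saturated chain carbon bound to an oxygen on an aromatic ring, here it goes onto a saturated chain carbon bound to an aromatic carbon. Among the measured compounds shown here, the earlier step is the only guide available for how this sort of lengthening behaves in this assay.

From compound 3 to compound 4 a step of a number 17 percentage points lower from compound 3 to compound 4 (beyond the scatter) is expected in this assay, smaller than the earlier one because compound 3 already starts from 42% and has less room to fall. For compound 4 the expected value in this assay is therefore 25%, with a plausible range from 5% to 48%.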

Compound 4, a percentage reported as inhibition, in the whole organism at one dose (the size of the read-out at that dose, not a potency): 26%
Compound 4: middle estimate off by 1 percentage points, on the low side, within the range that was stated.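

In this assay, adding one methyl on a saturated chain carbon bound to an aromatic carbon, which turns a methyl into an ethyl, gave a number 16 percentage points lower from compound 3 to compound 4 (beyond the scatter), so this lengthening went with less inhibition at the dose given. Among these compounds, this does not amount to a rule for the series: only two pairs carry the change, the new methyl sits at a different kind of place in each, and a percentage at one dose in a whole organism is not a potency, so neither pair explains why the number drops. What can be said is that the drop carried over from one core to the other in direction, and its size did not differ measurably between the two:  the same change on two cores in this assay, a number 24 percentage points lower (beyond the scatter) from compound 1 to compound 2 and a number 16 percentage points lower (beyond the scatter) from compound 3 to compound 4, 8 percentage points apart, within the scatter of two such steps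

The compounds shown leave open whether a longer chain, such as propyl or butyl, at these same places would lower the number further or leave it where it is. They also leave open how a group of another kind, such as an amine or a carboxylic acid at the end of that chain, would behave on either core.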